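Series notes: aryl loss on the benzamide end

The compounds below may be only part of what the source reports. "The series", "measured", "known", "first", "only" and "open" are said of these compounds alone.

The shared core is carried in compound 1 `CCOc1cc(NC(=O)CCCCC(=O)Nc2cc(-c3ccc(C)s3)ccc2N)cc2c1OCC([N+](=O)[O-])=C2` and in compound 2 `CCOc1cc(NC(=O)CCCCCNC(=O)CCCc2ccccc2)cc2c1OCC([N+](=O)[O-])=C2`. Among the measured compounds shown here, in a functional assay on PC-3 cells (Homo sapiens) for antiproliferative activity, read by MTT assay, with a stated time of 48 h (a higher number here means a weaker inhibitor of growth, a lower number a stronger inhibitor of growth), compound 1 gives 13500 nM, the higher of the two numbers so far; compound 2 gives 7170 nM, and the two values lie within the scatter of each other, so no order between them is claimed. For the measured compounds named here, no step between measured compounds that differ in a single place is available in this set.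

Compound 3 `CCOc1cc(NC(=O)CCCCC(=O)Nc2ccccc2N)cc2c1OCC([N+](=O)[O-])=C2` is the next member to be measured. It differs from compound 1 in one place: hydrogen in place of 5-methylthiophen-2-yl on an aromatic carbon. Going by the values given here, no measured pair reports this kind of change, so the size of the step is an open question. The expectation is for a step of moderate size toward a higher number, that is, a weaker inhibitor of growth, since the remaining members of the set give no support for an improvement here. For compound 3 the estimated value in this assay is 30000 nM, with a range from 9000 nM to 100000 nM. This estimate corresponds to an expected step of a 2.2-fold higher number from compound 1 to compound 3 (0.35 log units; beyond the scatter).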

Compound 3, concentration for 50% growth inhibition: 18900 nM
The estimate for compound 3 lay 1.6-fold (0.20 log units) above the measured number; low and high end bracket the measured number.
By their numbers in this assay, from the lowest: compounds 2, 1 and 3 (each within the scatter of the next, the first and the last beyond it).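

In this assay, among the compounds shown here, hydrogen in place of 5-methylthiophen-2-yl on the aromatic carbon para to the amino group gives a 1.4-fold higher number from compound 1 to compound 3 (0.15 log units; within the scatter), the first comparison that changes a single place. Removing all six heavy atoms of this group, including its five-membered aromatic ring, therefore leaves no readable difference in this assay, and at this position the 5-methylthiophen-2-yl group shows no contribution that can be separated from the scatter. No measurement at hand offers an explanation for this outcome.

On these data alone, with only hydrogen and 5-methylthiophen-2-yl seen at this position, it remains open whether a different group, such as a phenyl ring, a fluorine atom or a methoxy group, would produce a step beyond the scatter in either direction. Also open, as far as these compounds go, is whether the amino group on the same ring matters to the values in this assay, for instance when a hydroxyl group takes its place, and whether the lack of a readable step at the 5-methylthiophen-2-yl position would hold with another linking chain.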